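The compounds below may be only part of what the source reports. "The series", "measured", "known", "first", "only" and "open" are said of these compounds alone.

Compound 1 `C[S+]([O-])/C=C/c1cc(=O)c2cc(Cl)ccc2o1` gives 1700 nM in a functional assay on A549 cells (Homo sapiens) for cytotoxicity, with a stated time of 48 h; on this read-out lower numbers stand for stronger inhibition and higher numbers for weaker inhibition; compound 2 `CCCCOc1ccc2oc(/C=C/[S+](C)[O-])cc(=O)c2c1` gives 1400 nM in this assay.

Only these two compounds have been measured, and they differ in one place: the step of a 1.2-fold lower number from compound 1 to compound 2 (0.08 log units; within the scatter) is within the scatter of repeated measurements, so the two numbers cannot be told apart. Compound 2 therefore stands side by side with compound 1, with nothing to separate them.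

Compound 3 `CCCCC(=O)Oc1ccc2oc(/C=C/[S+](C)[O-])cc(=O)c2c1` is not yet measured. It differs from compound 2 by butylcarbonyl in place of butyl on an oxygen on an aromatic ring. For the measured compounds named here, the only measured step, from compound 1 to compound 2, changes a different part of the shared core and leaves the group on this oxygen untouched, so no step bears directly on the change now considered. Without such a step, nothing points to a shift in either direction, and a step within the scatter is the plainest expectation. Compound 3 is thus expected to give about 1500 nM in this assay, with a range from 500 nM to 4500 nM, the estimated step being a 1.1-fold higher number from compound 2 to compound 3 (0.03 log units; within the scatter).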

Compound 3, half-maximal inhibitory concentration: 2400 nM
Compound 3: the middle estimate sits 1.6-fold (0.20 log units) below what was measured; measured number inside the range.
By their numbers in this assay, from the lowest: compounds 2, 1 and 3 (each within the scatter of the next).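

Putting butylcarbonyl in place of butyl on this oxygen on an aromatic ring brings in a carbonyl and a hydrogen-bond acceptor, yet in this assay the result is a 1.7-fold higher number from compound 2 to compound 3 (0.23 log units; within the scatter), so compound 2 and compound 3 cannot be told apart. The comparison with the chloro group gives the same answer, with a 1.4-fold higher number from compound 1 to compound 3 (0.15 log units; within the scatter), so chloro, butoxy and (butylcarbonyl)oxy at this place on the shared core all give numbers that lie within the scatter of one another, and this change adds a new kind of link to that place without separating the compounds. Nothing measured alongside these numbers speaks to what lies behind them.

These three compounds leave open whether any group at this place can move the number beyond the scatter, for instance a free hydroxyl, an amine, a carboxylic acid, or a much longer chain on the oxygen. They also say nothing about changes elsewhere on the core, such as replacing the methyl on the sulfur with an ethyl group.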